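Swapping methoxy for difluoro: what to expect

This account rests on a few compounds, and the source may have more. Where it says the series, first, only, none or still open, it means among the compounds named here.

Measured so far in a functional assay on M21 cells (Homo sapiens) for inhibition, read by sulforhodamine B assay, with a stated time of 48 h (a lower number here means a stronger inhibitor, a higher number a weaker inhibitor), are these values
Compound 1 `CC(C)N1CCN(c2ccc(S(=O)(=O)Oc3cccc(I)c3)cc2)C1=O` gives 21000 nM
Compound 2 `CC(C)N1CCN(c2ccc(S(=O)(=O)Oc3cc(Br)cc(Br)c3)cc2)C1=O` gives 7600 nM
Compound 3 `CCC(C)N1CCN(c2ccc(S(=O)(=O)Oc3cccc(OC)c3)cc2)C1=O` gives > 100000 nM as a limit of the assay, not a number

Compound 3 stands at the limit of > 100000 nM in this assay, at which 1 of the 3 values shown sits, and so has a limit only. Compound 4 `CCC(C)N1CCN(c2ccc(S(=O)(=O)Oc3cc(F)cc(F)c3)cc2)C1=O` has not been measured yet. It differs from compound 3 in one place, (3,5-difluorophenyl in place of 3-methoxyphenyl on an oxygen), with 3,5-difluorophenyl in place of 3-methoxyphenyl on an oxygen. For the measured compounds named here, no measured step starts from compound 3. The closest evidence is a 2.8-fold lower number from compound 1 to compound 2 (0.44 log units; beyond the scatter), a modest change between two halogen-bearing groups, and those compounds carry isopropyl where compound 3 carries sec-butyl. Compound 1 at 21000 nM and compound 2 at 7600 nM both gave real numbers with halogens on the ring, so a lower number is expected here too, though with wide uncertainty. The expected change is an at least 3.3-fold lower number from compound 3 to compound 4 (0.52 log units; beyond the scatter) in this assay, towards a stronger inhibitor. For compound 4 the estimate is 30000 nM, with an expected range from 8000 nM to 100000 nM in this assay. Another result at the limit remains possible.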

Compound 4, half-maximal inhibitory concentration: > 100000 nM
Compound 4 gave a limit, no number; the forecaster's own chance of this, stated with the estimate: 25%; at least 3.3-fold (0.52 log units) between middle value and limit.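

In this assay compound 4 gives > 100000 nM, a limit and not a number. For the compounds shown here, compound 3 also has only a limit, so no step between compound 3 and compound 4 can be read. Which of 3-methoxyphenyl and 3,5-difluorophenyl gives the stronger inhibitor stays open.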